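This account rests on a few compounds, and the source may have more. Where it says the series, first, only, none or still open, it means among the compounds named here.

Among the three compounds measured so far in an assay on isolated protein for inhibition of Amine oxidase [flavin-containing] B (Homo sapiens) (on this read-out higher numbers stand for weaker inhibition and lower numbers for stronger inhibition), compound 3 `C#CCNC1CCc2c(SCc3ccc(C(F)(F)F)cc3)cccc21` carries the highest number: compound 3 gives 9680 nM. Compound 1 `C#CCNC1CCc2c(SCc3ccc(Br)cc3)cccc21` gives 1310 nM, and compound 2 `C#CCNC1CCc2c(SCc3ccc(F)cc3F)cccc21` gives 2430 nM. Both of these sit well below compound 3, and since its separation from each of the other two lies beyond the scatter, compound 3 is the weakest inhibitor of the set.

The next compound, compound 4 `C#CCNC1CCc2c(SCc3ccc(OC)cc3)cccc21`, differs from compound 3 in a single place: methoxy in place of trifluoromethyl on an aromatic carbon. For the measured compounds named here, only one measured step bears on an exchange at this place, a 7.4-fold higher number from compound 1 to compound 3 (0.87 log units; beyond the scatter), which shows that swapping the group there can shift the number by a clear margin. Compound 2 is not joined to compound 3 by a single-place step; its value only shows that it stands between compound 1 and compound 3. Going by the values given here, no measured compound carries a methoxy group, so the direction of the change rests on the general observation that the other groups tried at this place all gave lower numbers than trifluoromethyl.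

On that basis the number for compound 4 is expected to fall, by a step estimated as a 3.2-fold lower number from compound 3 to compound 4 (0.51 log units; beyond the scatter). For compound 4 the estimate in this assay is 3000 nM, with a range from 800 nM to 12000 nM.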

Compound 4, half-maximal inhibitory concentration: 1900 nM
Compound 4: the middle estimate sits 1.6-fold (0.20 log units) above what was measured, within the range that was stated.
By their numbers in this assay, from the lowest: compounds 1, 4 and 2 (each within the scatter of the next); then compound 3.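

At this place, on an aromatic carbon para to a large group, this assay now separates trifluoromethyl from a second group, since the exchange for methoxy gives a 5.1-fold lower number from compound 3 to compound 4 (0.71 log units; beyond the scatter) and stands beyond the scatter. The earlier exchange for bromo could have marked a feature of that single pair, but among compounds 1, 3 and 4, which differ only at this place, trifluoromethyl now stands alone with the highest number. Methoxy and bromo cannot be told apart on this read-out, as the exchange between them gives a 1.5-fold higher number from compound 1 to compound 4 (0.16 log units; within the scatter) and lies within the scatter, and nothing at hand gives a reason for either result.

The compounds shown leave open whether a plain hydrogen at this place would give a number close to those of compound 1 and compound 4, and whether other groups, such as an amine, a carboxylic acid, a nitrile or a longer chain like ethoxy, would stay with them or move towards compound 3. They also leave open whether the same order of bromo, methoxy and trifluoromethyl would hold with these groups elsewhere on the ring.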